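This account rests on a few compounds, and the source may have more. Where it says the series, first, only, none or still open, it means among the compounds named here.

Working notes on the series, all read in a functional assay on MGC-803 cells (Homo sapiens) for antiproliferative activity, read by CCK-8 assay, with a stated time of 72 h, tested at 8 uM; on this read-out lower numbers stand for a weaker effect and higher numbers for a stronger effect at the one concentration tested. Compound 1 `Nc1ccccc1NC(=O)c1ccc(CSC(=S)N2CCN(c3ccccc3)CC2)cc1` gives 87.4%, the second highest of the three numbers measured; compound 3 `Nc1ccccc1NC(=O)c1ccc(CSC(=S)N2CCCc3ccccc32)cc1` gives 87.5% and compound 2 `CN(C(=S)SCc1ccc(C(=O)Nc2ccccc2N)cc1)c1cccnc1` gives 82.5%, both within the scatter of compound 1. Among the measured compounds shown here, the single measured step, a number 5 percentage points higher from compound 2 to compound 3 (within the scatter), concerns the group on the thiocarbonyl carbon and stays within the scatter. Compound 4 `Nc1ccccc1NC(=O)c1ccc(CSC(=S)N2CCN(c3ccncc3)CC2)cc1` carries pyridin-4-yl in place of phenyl on an amine nitrogen in a ring. For the measured compounds named here, no measured step alters the group on this ring nitrogen, so the only guide is that all three measured numbers sit within the scatter of one another; a step within the scatter is therefore expected for a number 2.4 percentage points lower from compound 1 to compound 4 (within the scatter). Compound 4 is estimated at 85%, with a range of 75% to 93%.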

Compound 4, a percentage reported as inhibition, at one concentration (the size of the read-out at that concentration, not a potency): 87.1%
For compound 4 the middle estimate is 2.1 percentage points below the measured one, and the stated range covers the measured number.
By their numbers in this assay, from the lowest: compounds 2, 4, 1 and 3 (each within the scatter of the next).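

In this assay, among the compounds shown here, the step of a number 0.3 percentage points lower from compound 1 to compound 4 (within the scatter) is the one measured change on this amine nitrogen in a ring, and it stays within the scatter. Pyridin-4-yl, with its ring nitrogen and one hydrogen-bond acceptor by count, therefore reads the same as phenyl here at the single concentration tested. No measured evidence accompanies this result. The compounds shown leave open whether a non-aromatic group on this nitrogen, such as methyl or acetyl, would shift the number. They also leave open whether compound 1 and compound 4 would still match in a full concentration series.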